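The source may hold more compounds than are shown below. What is called first, only, known or untested is meant among the compounds shown, and "the series" means these compounds.

The measured compounds:
Compound 1 `CCCCC#Cc1cn([C@@H]2O[C@H](CO)[C@@H](O)[C@H]2O)c(=O)[nH]c1=O`, measured in an ADME assay on Vero cells (Chlorocebus sabaeus) for cytotoxicity, read by MTT assay; on this read-out higher numbers stand for lower toxicity in this test and lower numbers for higher toxicity in this test: 103000 nM
Compound 2 `CCCCC#Cc1c[nH]c(=O)[nH]c1=O`, measured in this assay: 253000 nM

Of these two numbers, compound 1 gives the lower one in this assay, and compound 2 stands higher by a margin that lies beyond the usual scatter. Among the compounds with values here, no pair of measured compounds differing in a single place is available, so the route from compound 1 to compound 3 has to be judged from the structural change alone. Compound 3 `CCCCCCC#Cc1cn([C@@H]2O[C@H](CO)[C@@H](O)[C@H]2O)c(=O)[nH]c1=O` differs from compound 1 in this way: ethyl in place of hydrogen on a saturated chain carbon, four bonds along the chain from a triple-bonded carbon. Everything else, including the core of compound 1, stays the same. Lengthening a saturated chain by ethyl usually moves a number of this kind only modestly. In this assay compound 3 is expected to land a little lower than its parent, a step estimated at a 1.5-fold lower number from compound 1 to compound 3 (0.17 log units; within the scatter). The estimate for compound 3 is 70000 nM, with a range from 25000 nM to 200000 nM.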

Compound 3, half-maximal cytotoxic concentration: 111000 nM
Beside the measured number, compound 3's estimate is 1.6-fold (0.20 log units) below it; measured number inside the range.
By their numbers in this assay, from the lowest: compounds 1 and 3 (each within the scatter of the next); then compound 2.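

In this assay, adding ethyl in place of hydrogen on a saturated chain carbon, four bonds along the chain from a triple-bonded carbon, gives a 1.1-fold higher number from compound 1 to compound 3 (0.03 log units; within the scatter) and so leaves the two compounds indistinguishable on this read-out. Within the data shown here, this is the first sign that this position can take a longer saturated chain without a readable difference in the number, although it rests on a single pair of compounds. Nothing available here offers an explanation for this result.

Still open, as far as these compounds go, is whether a much longer chain, or a different kind of group at this position such as an amine or a carboxylic acid, would also stay within the scatter. Also open, from the compounds shown here alone, is whether the same ethyl would give a similar step on compound 2.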